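A few compounds are considered here, and "the series" means these few. Any claim that something is new, unique, unknown or untested is made for them only; others in the source may bear on it.

Of the compounds shown here, three with a shared core have been read in a functional assay on PA-1 cells (Homo sapiens) for antiproliferative activity, read by MTT assay, with a stated time of 48 h; a higher number here means a weaker inhibitor, a lower number a stronger inhibitor. Compound 1 `CCN1C(=O)C(O)(Cc2nnn[nH]2)c2ccccc21` gives > 100000 nM, which is a limit and not a number. Going by the values given here, compound 2 `CCN1C(=O)C(O)(Cc2nnn[nH]2)c2cc(Cl)ccc21`, with chloro in place of hydrogen on an aromatic carbon, gives 49500 nM, the only true number so far. Compound 3 `CN1C(=O)C(O)(Cc2nnn[nH]2)c2cc(Br)ccc21` gives > 100000 nM, again a limit and not a number. Compound 3 therefore has no measured position of its own and stands at the limit of > 100000 nM in this assay, at which 2 of the 3 values shown sit.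

Compound 4 `CCN1C(=O)C(O)(Cc2nnn[nH]2)c2cc(Br)ccc21` departs from compound 3 by methyl in place of hydrogen on a saturated chain carbon bound to an amide-type nitrogen in a ring, or methyl to ethyl when cut one bond further out. Among the compounds with values here, no measured step covers this change. Within the data shown here, the only step available is an at least 2.0-fold lower number from compound 1 to compound 2 (0.30 log units; that floor lies within the scatter), and it concerns a different place, so it bears on the question only loosely. Among the measured compounds shown here, a modest move to a lower number in this assay is expected, with compound 2 at 49500 nM as the sole guide. Compound 4 may still reach the limit. The expected change is an at least 1.6-fold lower number from compound 3 to compound 4 (0.22 log units; that floor lies within the scatter). For compound 4 the estimated value is 60000 nM, with an expected range from 25000 nM to 100000 nM.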

Compound 4, half-maximal inhibitory concentration: > 100000 nM
Compound 4 gave a limit, no number (the forecaster's own chance of this, stated with the estimate: 40%); at least 1.6-fold (0.22 log units) between middle value and limit.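

In this assay, methyl to ethyl at this place, on a saturated chain carbon bound to an amide-type nitrogen in a ring, did not bring the bromo compound to a true number, and the series now gathers at one limit: the limit of > 100000 nM in this assay, at which 3 of the 4 values shown sit. Compound 4 and compound 3 both stand at limits, as does compound 1, so the steps joining compound 4 to each of them cannot be read. Going by these compounds alone, the one readable comparison is bromo in place of chloro on an aromatic carbon, an at least 2.0-fold higher number from compound 2 to compound 4 (0.30 log units; that floor lies within the scatter), which leaves compound 2 as the only compound with a true number, although the size of this step stays open-ended and its floor lies within the scatter.

As far as these compounds go, whether methyl to ethyl changes the activity at all remains unknown, since the bromo pair gives limits only. Also open, from the compounds shown here alone, is whether a longer chain such as propyl at this place, or an amine or a carboxylic acid on the aromatic carbon in place of the halogen, would give a true number in this assay.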